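The source may report more compounds than this note shows. Statements on the series, on what has been measured and on what is new or still open speak of the compounds shown alone.

Working notes on the series.

For the measured compounds named here, compound 1 `Brc1cccc2c1nnn2CC1CC1` is the only member of this set with a number in an ADME assay on microsomes from liver (Homo sapiens) for metabolic stability, tested at 2.5 uM; a lower number here means slower removal, a higher number faster removal of the compound: compound 1 gives 1.3 mL/min/g, and it therefore stands alone on the scale. Compound 2 `COc1cc(Br)c2nnn(CC3CC3)c2c1` carries a methoxy group in addition, and for compound 2 the result in this assay is "not determined" (no result reported), so it adds nothing to the comparison. Compound 3 `FC(F)(F)c1cccc2c1nnn2CC1CC1` is the next analogue, not yet measured, and differs from compound 1 in one place: trifluoromethyl in place of bromo on an aromatic carbon. Going by the values given here, no step between two measured compounds exists to calibrate this exchange, so only the single reading of compound 1 anchors the expectation. The exchange of bromo for trifluoromethyl on the aromatic carbon is expected to move clearance little, if at all, with any shift most likely within the usual scatter, and compound 3 is expected at 1.1 mL/min/g (range 0.5 mL/min/g to 2.5 mL/min/g), corresponding to an estimated step of a 1.2-fold lower number from compound 1 to compound 3 (0.07 log units; within the scatter).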

Compound 3, intrinsic clearance in a liver preparation (reported as CLH), per the amount of preparation that the assay uses: 0.3 mL/min/g
The estimate for compound 3 lay 3.7-fold (0.56 log units) above the measured number; measured number outside the range, below it.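

In this assay, for the compounds shown here, trifluoromethyl in place of bromo on this aromatic carbon gives a 4.3-fold lower number from compound 1 to compound 3 (0.64 log units; beyond the scatter) and so supplies the first calibrated step. The number therefore depends on which of these two groups occupies the position, which the lone reading of compound 1 could not show. The available data offer no explanation for the size or direction of this step.

From the compounds shown here alone, the step rests on a single pair, so it remains open how a nitrile, an amine or a carboxylic acid on the same carbon would compare with bromo and trifluoromethyl. Going by these compounds, it is also open whether the same exchange would give a step of similar size on a core carrying a further group such as methoxy.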